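This account rests on a few compounds, and the source may have more. Where it says the series, first, only, none or still open, it means among the compounds named here.

Compound 3 `c1ccc(C[C@H](CCn2cncn2)c2ccccc2)cc1` is the starting point here, and compound 4 `c1ccc(C[C@@H](CCn2cncn2)c2ccccc2)cc1` is the compound whose number is awaited. In an ADME assay on HEp-2 cells (Homo sapiens) for cytotoxicity, read by MTT assay, with a stated time of 3 days (a lower number here means that less compound is tolerated, a higher number that more compound is tolerated), compound 3 gives 60.9 ug/mL, the second highest of the three numbers measured: compound 1 `CC[C@@H](CCn1cncn1)c1ccccc1` gives 89.9 ug/mL and compound 2 `CCCC[C@@H](CCn1cncn1)c1ccccc1` gives 40.8 ug/mL, and compound 3 lies within the usual scatter of each of them. For the measured compounds named here, the only measured step that changes a single place is a 2.2-fold lower number from compound 1 to compound 2 (0.34 log units; beyond the scatter), which concerns an added ethyl group rather than configuration. Compound 4 differs from compound 3 as follows: the two compounds have the same atoms and bonds and differ only in configuration as drawn: 1 of 1 stereo elements differ; a stereocentre at a saturated chain carbon is drawn R in compound 3 and S in compound 4. Going by the values given here, no measured pair differs only in configuration, so there is no step on which an expectation of a shift could rest. Compound 4 is therefore expected to give a number close to that of compound 3, with the expected step being a 1.0-fold lower number from compound 3 to compound 4 (0.01 log units; within the scatter). The estimate for compound 4 in this assay is 60 ug/mL, with a range from 30 ug/mL to 120 ug/mL.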

Compound 4, half-maximal cytotoxic concentration: 55.9 ug/mL
The estimate for compound 4 lay 1.1-fold (0.03 log units) above the measured number; the measured number falls inside the stated range.
By their numbers in this assay, from the lowest: compounds 2, 4, 3 and 1 (each within the scatter of the next, the first and the last beyond it).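

In this assay, reversing the single stereocentre at the saturated chain carbon gives a 1.1-fold lower number from compound 3 to compound 4 (0.04 log units; within the scatter), so this position now has a step in configuration alone, and that step can be read cleanly for one reason: the fact that compounds 3 and 4 differ only in the configuration as drawn. At the same chain carbon, phenyl in place of propyl gives a 1.4-fold higher number from compound 2 to compound 4 (0.14 log units; within the scatter), and phenyl in place of methyl gives a 1.6-fold lower number from compound 1 to compound 4 (0.21 log units; within the scatter). Of all the steps shown, only a 2.2-fold lower number from compound 1 to compound 2 (0.34 log units; beyond the scatter) lies beyond the scatter, so neither the change of configuration nor these two swaps to phenyl separates compound 4 from its neighbours.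

The compounds shown leave open whether configuration counts for as little with the chains of compound 1 and compound 2. They also leave open how an amine or a carboxylic acid on this chain carbon would compare.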